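A few compounds are considered here, and "the series" means these few. Any claim that something is new, unique, unknown or untested is made for them only; others in the source may bear on it.

Measured compounds: compound 1 `CC(=O)N1CCC(NC(=O)c2ccncc2Nc2cc(-c3ccc4ccn(C)c4c3)c3nccnc3c2)CC1` and compound 2 `CN1CCC(NC(=O)c2ccncc2Nc2cc(-c3ccc4ccn(C)c4c3)c3nccnc3c2)CC1=O`.

In an assay on lysate for inhibition of 6-phosphofructo-2-kinase/fructose-2,6-bisphosphatase 3 (Homo sapiens), with stated times of 0.5 min and 45 min (a higher number here means a weaker inhibitor, a lower number a stronger inhibitor), compound 1 gives 31300 nM. In this assay compound 2 gives 48800 nM. Compound 2 thus stands at the upper end of the two numbers, but the step of a 1.6-fold higher number from compound 1 to compound 2 (0.19 log units; within the scatter) is within the scatter, so the two compounds cannot be told apart on these data.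

Compound 3 `CC(=O)N1CCCC(NC(=O)c2ccncc2Nc2cc(-c3ccc4ccn(C)c4c3)c3nccnc3c2)C1` has not been measured. It differs from compound 2 in one place: 1-acetylpiperidin-3-yl in place of 1-methyl-2-oxopiperidin-4-yl on an amide-type nitrogen. For the measured compounds named here, the only measured step that bears on this position is the one from compound 1 to compound 2, in which the 1-acetylpiperidin-4-yl group gave way to the 1-methyl-2-oxopiperidin-4-yl group, and that step was a 1.6-fold higher number from compound 1 to compound 2 (0.19 log units; within the scatter). Compound 3 returns to an acetylpiperidinyl group, now a 1-acetylpiperidin-3-yl, so the closest reference is compound 1 as much as compound 2. On this basis no step beyond the scatter is expected in this assay; the expected step is a 1.4-fold lower number from compound 2 to compound 3 (0.14 log units; within the scatter). For compound 3 the estimate in this assay is 35000 nM, with a range from 12000 nM to 100000 nM.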

Compound 3, half-maximal inhibitory concentration: 13500 nM
Estimate against measurement, compound 3: 2.6-fold (0.41 log units) above, and the stated range covers the measured number.
By their numbers in this assay, from the lowest: compound 3; then compounds 1 and 2 (each within the scatter of the next).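

In this assay, 1-acetylpiperidin-3-yl in place of 1-acetylpiperidin-4-yl on the amide-type nitrogen gives a 2.3-fold lower number from compound 1 to compound 3 (0.37 log units; beyond the scatter), and the same group in place of 1-methyl-2-oxopiperidin-4-yl gives a 3.6-fold lower number from compound 2 to compound 3 (0.56 log units; beyond the scatter). For the compounds shown here, the earlier pair could not be told apart, so these modest steps are the first evidence that the number in this assay responds to a change at this position, and the step from the 4-yl to the 3-yl form of the acetylpiperidinyl group shows that the point of attachment matters with the acetyl group retained. The data available offer no explanation for the lower number given by the 1-acetylpiperidin-3-yl group.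

The compounds shown leave open whether the acetyl group is needed in the 3-yl series, as a free piperidin-3-yl amine or a 1-methylpiperidin-3-yl group would test. They also leave open whether the step carries over to other ring sizes, such as a 1-acetylpyrrolidin-3-yl group, or to a 1-methyl-2-oxopiperidin-3-yl group on the same amide-type nitrogen.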